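The compounds below may be only part of what the source reports. "The series", "measured", "known", "first", "only" and "open" are said of these compounds alone.

Compound 1, `COc1cc(N2C(N)=C(C#N)C(c3c(OC)ccc4ccccc34)C3=C2CC(C)(C)CC3=O)cc(OC)c1OC`, in a functional assay on Ehrlich cells (Mus musculus) for cytotoxicity, tested at 50 ug/mL (on this read-out higher numbers stand for a stronger effect at the one concentration tested and lower numbers for a weaker effect), gives 10%.
Compound 2, `COc1cc(N2C(N)=C(C#N)C(c3c(O)ccc4ccccc34)C3=C2CC(C)(C)CC3=O)cc(OC)c1OC`, in this assay gives 15%.

Compound 2 stands at the top of the two numbers shown, but its only neighbour is compound 1, and the step of a number 5 percentage points higher from compound 1 to compound 2 (within the scatter) lies within the scatter, so the two compounds are not separated by this assay. Compound 3, `COc1cc(N2C(N)=C(C#N)C(c3ccc(O)cc3)C3=C2CC(C)(C)CC3=O)cc(OC)c1OC`, differs from compound 2 in one place: 4-hydroxyphenyl in place of 2-hydroxynaphthalen-1-yl on a saturated ring carbon. Within the data shown here, no measured step bears directly on this change; the single step from compound 1 to compound 2 concerned hydrogen in place of methyl on an oxygen on an aromatic ring, a different alteration, and it was small. With nothing in the data pointing either way, compound 3 is expected to land near compound 2, with a step of a number 3 percentage points lower from compound 2 to compound 3 (within the scatter) that stays inside the scatter. The estimate for compound 3 in this assay is 12%, ranging from 0% to 30%.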

Compound 3, a percentage reported as activity, at one concentration (the size of the read-out at that concentration, not a potency): 90%
Beside the measured number, compound 3's estimate is 78 percentage points below it; measured number outside the range, above it.
By their numbers in this assay, from the lowest: compounds 1 and 2 (each within the scatter of the next); then compound 3.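

Among these compounds, on the saturated ring carbon next to the ring atom that bears a cyano group, the choice of aromatic group matters greatly in this assay: 4-hydroxyphenyl in place of 2-hydroxynaphthalen-1-yl gives a number 75 percentage points higher from compound 2 to compound 3 (beyond the scatter) and is the first change that separates compounds here. The same holds for 4-hydroxyphenyl in place of 2-methoxynaphthalen-1-yl, with a number 80 percentage points higher from compound 1 to compound 3 (beyond the scatter), so the large step appears from either naphthalenyl group. Nothing available explains a step of this size.

The exchange removes one aromatic ring and also alters where the hydroxyl stands, and these compounds do not separate the two changes. From the compounds shown here alone, it also remains open whether phenyl, 4-methoxyphenyl or 4-aminophenyl on this carbon would give a value like that of compound 3.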